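A few compounds are considered here, and "the series" means these few. Any claim that something is new, unique, unknown or untested is made for them only; others in the source may bear on it.

Measured so far:
compound 1, `CCCS(=O)(=O)Nc1ccc(F)c(C(=O)c2n[nH]c3ncc(-c4ccccc4OC)cc23)c1F`: 1.9%
compound 2, `CCCS(=O)(=O)Nc1ccc(F)c(C(=O)c2n[nH]c3ncc(-c4cccc(OC)c4)cc23)c1F`: 6.3%
compound 3, `CCCS(=O)(=O)Nc1ccc(F)c(C(=O)c2n[nH]c3ncc(-c4cccc(N)c4)cc23)c1F`: 1.6%

These values come from an assay for binding affinity to dual specificity mitogen-activated protein kinase kinase 4 (Homo sapiens), read by KINOMEscan, tested at 100 nM; a lower number here means a stronger effect, a higher number a weaker effect of the compound at the concentration tested. Compound 2 carries the highest of the three numbers, but its gaps to the others, a number 4.4 percentage points higher from compound 1 to compound 2 (within the scatter) and a number 4.7 percentage points lower from compound 2 to compound 3 (within the scatter), lie within the scatter, as does a number 0.3 percentage points lower from compound 1 to compound 3 (within the scatter), so no order among the three can be drawn.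

Compound 4, `CCCS(=O)(=O)Nc1ccc(F)c(C(=O)c2n[nH]c3ncc(-c4ccc(C(C)(C)C)cc4)cc23)c1F`, is not yet measured. Change from compound 2: 4-(tert-butyl)phenyl in place of 3-methoxyphenyl on an aromatic carbon. Among the compounds with values here, the steps that bear on this are the two exchanges at the same aromatic carbon, a number 4.4 percentage points higher from compound 1 to compound 2 (within the scatter) and a number 4.7 percentage points lower from compound 2 to compound 3 (within the scatter), both within the scatter. The entering group is the largest so far, which widens the uncertainty, but no step beyond the scatter is expected. Compound 4 is expected at 6%, range 1% to 20%, an expected a number 0.3 percentage points lower from compound 2 to compound 4 (within the scatter).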

Compound 4, a percentage reported as activity, at one concentration (the size of the read-out at that concentration, not a potency): 46%
Compound 4: the middle estimate sits 40 percentage points below what was measured, and the stated range ends below it.
By their numbers in this assay, from the lowest: compounds 3, 1 and 2 (each within the scatter of the next); then compound 4.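

In this assay this aromatic carbon is not indifferent to its aryl group: 4-(tert-butyl)phenyl gives a number 39.7 percentage points higher from compound 2 to compound 4 (beyond the scatter) and a number 44.4 percentage points higher from compound 3 to compound 4 (beyond the scatter) and a number 44.1 percentage points higher from compound 1 to compound 4 (beyond the scatter), whereas the three earlier aryl groups lie within the scatter of one another. Nothing at hand accounts for this step.

Open, as far as these compounds go, is whether the step follows the tert-butyl group itself or the place of the substituent on the phenyl ring. A 4-methoxyphenyl or a 3-(tert-butyl)phenyl at this carbon would separate the two.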